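A few compounds are considered here, and "the series" means these few. Any claim that something is new, unique, unknown or untested is made for them only; others in the source may bear on it.

Of the compounds shown here, three have been tested in a functional assay on CEM-DNR-bulk cells (Homo sapiens), read by MTT assay, with a stated time of 72 h (on this read-out higher numbers stand for weaker inhibition and lower numbers for stronger inhibition), and a fourth waits to be measured. Compound 1 `COc1nc(N)nc2c1c(-c1cc3ccccc3o1)cn2[C@@H]1O[C@H](CO)[C@@H](O)[C@H]1O` carries a benzofuranyl group on its core and gives 16700 nM. Compound 2 `COc1ncnc2c1c(I)cn2[C@@H]1O[C@H](CO)[C@@H](O)[C@H]1O` carries an iodo group at the same place; its result is a limit of the assay, > 20000 nM, so no number is known for it. Compound 3 `Nc1nc(N)c2c(-c3ccoc3)cn([C@@H]3O[C@H](CO)[C@@H](O)[C@H]3O)c2n1` also comes back only as a limit, > 20000 nM. Compound 2 therefore stands among the weakest results shown, and it shares the limit of > 20000 nM in this assay, at which 2 of the 3 values shown sit, with compound 3, while compound 1 is the only one with a numerical value.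

Compound 4 `COc1ncnc2c1c(-c1ccsc1)cn2[C@@H]1O[C@H](CO)[C@@H](O)[C@H]1O` differs from compound 2 by a single change: thiophen-3-yl in place of iodo on an aromatic carbon. For the measured compounds named here, since no step between measured compounds is available, the expectation rests on the three values alone, and the only numerical value, that of compound 1 with an aromatic ring in this position, sits close to the limit. The expected step of an at least 1.1-fold lower number from compound 2 to compound 4 (0.04 log units; that floor lies within the scatter) is estimated to stay within the usual scatter. In this assay compound 4 is expected to give roughly 18000 nM, between 5000 nM and 60000 nM.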

Compound 4, half-maximal inhibitory concentration: 7640 nM
Compound 4: the middle estimate sits 2.4-fold (0.37 log units) above what was measured; measured number inside the range.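

In this assay, for the compounds shown here, thiophen-3-yl in place of iodo on this aromatic carbon gives an at least 2.6-fold lower number from compound 2 to compound 4 (0.41 log units; beyond the scatter), the first change at this position that can be read as a step. On this core, then, a five-membered aromatic ring with a sulfur atom brings the result down to a real number, and the position clearly responds to what it carries. The true size of the step stays unknown, because compound 2 gives only a limit of the assay: the limit of > 20000 nM in this assay, at which 2 of the 4 values shown sit.

With only one ring shown on this core, it stays open whether the drop belongs to thiophen-3-yl itself or would come with any aromatic ring at this carbon. The compounds shown also leave open how a phenyl ring, an ethyl chain or an amine at this carbon would behave in this assay.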